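Replacing the amide aryl group by cyclopentylmethyl

A few compounds are considered here, and "the series" means these few. Any claim that something is new, unique, unknown or untested is made for them only; others in the source may bear on it.

Three amides share one core. Compound 1 `O=C(Nc1cc(-c2ccccc2)nn1-c1ccccc1)c1ccc(C(F)(F)F)cc1` gives 38 nM in a functional assay on cells for positive allosteric modulation of metabotropic glutamate receptor 5 (Rattus norvegicus), read by calcium flux; a higher number here means that more compound is needed for the effect, a lower number that less compound is needed. Compound 2 `O=C(Nc1cc(-c2ccccc2)nn1-c1ccccc1)c1ccc([N+](=O)[O-])cc1` gives 10.7 nM. Compound 3 `Cc1ccc(C(=O)Nc2cc(-c3ccccc3)nn2-c2ccccc2)cc1C` gives 20 nM. Compound 3 holds the second highest number of the three: nearest is a 1.9-fold higher number from compound 2 to compound 3 (0.27 log units; within the scatter), furthest is a 1.9-fold lower number from compound 1 to compound 3 (0.28 log units; within the scatter), both within the scatter. Among the measured compounds shown here, the only step beyond the scatter is a 3.6-fold lower number from compound 1 to compound 2 (0.55 log units; beyond the scatter). Compound 4 `O=C(CC1CCCC1)Nc1cc(-c2ccccc2)nn1-c1ccccc1` differs from compound 3 in one place: cyclopentylmethyl in place of 3,4-dimethylphenyl on a carbonyl carbon. For the measured compounds named here, all three measured steps change the group on the carbonyl carbon, yet each keeps a six-membered aromatic ring there; none removes it, so no measured step bears directly on this change, and the expectation is wide. Compound 4 is estimated at 70 nM, expected between 15 nM and 400 nM. The expected step is a 3.5-fold higher number from compound 3 to compound 4 (0.54 log units; beyond the scatter), a modest rise.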

Compound 4, half-maximal effective concentration: 350 nM
The estimate for compound 4 lay 5.0-fold (0.70 log units) below the measured number; measured number inside the range.
By their numbers in this assay, from the lowest: compounds 2, 3 and 1 (each within the scatter of the next, the first and the last beyond it); then compound 4.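

In this assay, an aromatic ring on the carbonyl carbon proves far from interchangeable with cyclopentylmethyl: the change gives an 18-fold higher number from compound 3 to compound 4 (1.24 log units; beyond the scatter), and likewise a 33-fold higher number from compound 2 to compound 4 (1.51 log units; beyond the scatter) and a 9.2-fold higher number from compound 1 to compound 4 (0.96 log units; beyond the scatter). Each of these rises exceeds the largest step among the aromatic amides (a 3.6-fold lower number from compound 1 to compound 2 (0.55 log units; beyond the scatter)). Compound 4 alone cannot separate the loss of aromaticity from the other differences in the group, including ring size and the inserted carbon. Nothing available here explains the rise. Benzyl and cyclohexyl groups on the carbonyl carbon remain open as ways to separate these differences.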